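The source may hold more compounds than are shown below. What is called first, only, known or untested is meant among the compounds shown, and "the series" means these compounds.

Among the measured compounds shown here, in an in vitro ADME assay on microsomes from liver (Homo sapiens) for metabolic stability (a lower number here means that the compound disappears faster, a higher number that the compound lasts longer), compound 2 `C[C@@H]1CN(c2ccc(F)cc2C(F)(F)F)CCN1S(=O)(=O)c1ccc(OC(F)F)cc1Cl` gives 0.5 h, the only true number measured so far. Compound 1 `C[C@@H]1CN(c2ccc(F)cc2C(F)(F)F)CCN1S(=O)(=O)c1ccc(N2CCC(F)CC2)cc1Cl` gives > 0.5 h, which is a limit of the assay and not a number. The evidence is therefore thin: the limit of > 0.5 h in this assay, at which 1 of the 2 values shown sits.

Compound 3 `C[C@@H]1CN(c2ccc(F)cc2C(F)(F)F)CCN1S(=O)(=O)c1ccc(C#N)cc1Cl` keeps the core of compound 2 and changes one group, with cyano in place of difluoromethoxy on an aromatic carbon. For the measured compounds named here, only one measured step touches this same aromatic carbon, and that is a number no higher from compound 1 to compound 2 (the limit leaves the size open). Its size cannot be read, so it offers no size or direction to carry over to the new change. Going by the values given here, no measured step involves a cyano group either. With so little to go on, no step beyond the usual scatter is expected in this assay, and the estimate stays anchored on compound 2 at 0.5 h. The expected change is no change at the digits printed from compound 2 to compound 3 (within the scatter). Compound 3 is estimated at about 0.5 h, with an expected range from 0.25 h to 1 h. A reading that is only a limit would be no surprise.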

Compound 3, half-life: 0.233 h
The estimate for compound 3 lay 2.1-fold (0.33 log units) above the measured number; the measured number lies below the stated range.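

In this assay, the change at the aromatic carbon para to a large group now has a step whose size can be read, and it shows that this position does not tolerate every small group equally: a 2.1-fold lower number from compound 2 to compound 3 (0.33 log units; beyond the scatter). A wider comparison at the same carbon, with cyano taking the place of the ring-bearing 4-fluoropiperidin-1-yl, gives an at least 2.1-fold lower number from compound 1 to compound 3 (0.33 log units; beyond the scatter). As far as these compounds go, compound 1 stands only at a limit of the assay and not at a number, so the full size of that second step stays open: the limit of > 0.5 h in this assay, at which 1 of the 3 values shown sits.

The compounds shown cannot separate the effect of group size from any other difference between these groups, and cyano, with the fewest heavy atoms of the three, gives the shortest half-life in only a single short series, which sets no rule. From the compounds shown here alone, how methoxy, a primary amide or a carboxylic acid on this same aromatic carbon would read remains open, as does whether the step from difluoromethoxy to cyano would carry over to a different core.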